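This account rests on a few compounds, and the source may have more. Where it says the series, first, only, none or still open, it means among the compounds named here.

Measured compounds in this set:

compound 1, `CC(=O)N[C@H]1CC[C@@H](NS(=O)(=O)c2ccc(F)cc2)CC1`, 1 mg/kg
compound 2, `CCC(=O)N[C@H]1CC[C@H](NS(=O)(=O)c2ccc(F)cc2)CC1`, 1 mg/kg

In a functional assay on the whole organism with Mus musculus as the target, with a stated time of 20 min (on this read-out higher numbers stand for an effect only at larger amounts of compound and lower numbers for an effect already at smaller amounts), compound 1 gives 1 mg/kg. In this assay compound 2 gives 1 mg/kg, level with compound 1 at the digits recorded; the two values lie within the scatter of each other, so nothing can be said about which of the two is the more potent. Going by the values given here, no pair of measured compounds differing in a single place is available, so no measured step exists to calibrate the size of any change.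

Compound 3, `CCC(=O)N[C@H]1CC[C@@H](NS(=O)(=O)c2ccc(F)cc2)CC1`, is the next compound to be measured in this assay. Relative to compound 2 the change is the two compounds have the same atoms and bonds and differ only in configuration as drawn: 2 of 2 stereo elements differ (all stereocentres are inverted: mirror images); a stereocentre at a saturated ring carbon is drawn r in compound 2 and s in compound 3; a stereocentre at a saturated ring carbon is drawn r in compound 2 and s in compound 3. Among the compounds with values here, since both measured compounds sit at the same value and no step has been measured, there is no basis for predicting a shift in either direction; the step from compound 2 to compound 3 is expected to be no change at the digits printed from compound 2 to compound 3 (within the scatter), that is, none beyond the scatter. For compound 3 in this assay the estimate is 1 mg/kg, with a range of 0.5 mg/kg to 3 mg/kg.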

Compound 3, minimum effective dose: 0.1 mg/kg
The estimate for compound 3 lay 10-fold (1.00 log units) above the measured number; the whole stated range lies above it.
By their numbers in this assay, from the lowest: compound 3; then compounds 1 and 2 (each within the scatter of the next).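

In this assay the configuration as drawn at the two saturated ring carbons proves to matter, with a 10-fold lower number from compound 2 to compound 3 (1.00 log units; beyond the scatter). Going by these compounds alone, the shift can be assigned to configuration alone because nothing else separates the pair: the fact that compounds 2 and 3 differ only in the configuration as drawn With the configuration held as drawn, the chain on the carbonyl also proves responsive: methyl in place of hydrogen on a saturated chain carbon bound to a carbonyl carbon gives a 10-fold lower number from compound 1 to compound 3 (1.00 log units; beyond the scatter), a change the earlier compounds could not show, as no single-place pair existed among them.

The compounds shown leave open whether a longer chain, such as a butyl chain, or a cyclopropyl group on the carbonyl would lower the number further in this assay, and whether the configuration step would be of similar size with the shorter chain. Also open, as far as these compounds go, is how the number would respond to chlorine or a methoxy group in place of the fluorine, since that part of the structure stays constant across all the compounds here.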